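The source may report more compounds than this note shows. Statements on the series, on what has been measured and on what is new or still open speak of the compounds shown alone.

Measured compounds in an assay on isolated protein for binding affinity to 5-hydroxytryptamine receptor 6 (Homo sapiens); on this read-out lower numbers stand for stronger inhibition and higher numbers for weaker inhibition:
compound 1 `COc1ccc(S(=O)(=O)Nc2cc(Cl)cc(Cl)c2)cc1N1CCNCC1` gives 0.631 nM
compound 2 `COc1ccc(S(=O)(=O)Nc2cc(Br)cc(Br)c2Br)cc1N1CCNCC1` gives 2.51 nM
compound 3 `COc1ccc(S(=O)(=O)Nc2cc(Cl)cc(Cl)c2Br)cc1N1CCNCC1` gives 3.16 nM

Compound 3 has the highest of the three numbers in this assay. Its nearest neighbour is compound 2; the gap a 1.3-fold higher number from compound 2 to compound 3 (0.10 log units; within the scatter) lies within the scatter, so the two cannot be put in order. Its furthest is compound 1, with the step of a 5.0-fold higher number from compound 1 to compound 3 (0.70 log units; beyond the scatter) lying beyond the scatter.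

Compound 4 `COc1ccc(S(=O)(=O)Nc2cc(Br)cc(Cl)c2Cl)cc1N1CCNCC1` has not been measured. It differs from compound 3 by 5-bromo-2,3-dichlorophenyl in place of 2-bromo-3,5-dichlorophenyl on a sulfonamide nitrogen: the same three halogens are kept but are redistributed over the ring.

Among the compounds with values here, two measured steps bear on this change. The step of a 5.0-fold higher number from compound 1 to compound 3 (0.70 log units; beyond the scatter) shows that adding a halogen to the 3,5-dichlorophenyl of compound 1 costs a modest amount of affinity. The step of a 1.3-fold higher number from compound 2 to compound 3 (0.10 log units; within the scatter) shows that exchanging bromine for chlorine among three halogens on the ring moves the number by less than the scatter. Compound 4 keeps three halogens on the ring, as compound 2 and compound 3 do, and only exchanges which halogen sits at which named place. The expected step of a 1.1-fold lower number from compound 3 to compound 4 (0.02 log units; within the scatter) is therefore none beyond the scatter. Compound 4 is expected to give about 3 nM in this assay, with a range from 1.3 nM to 7 nM.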

Compound 4, inhibition constant: 3.98 nM
The estimate for compound 4 lay 1.3-fold (0.12 log units) below the measured number; the range from low to high includes it.
By their numbers in this assay, from the lowest: compound 1; then compounds 2, 3 and 4 (each within the scatter of the next).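

In this assay the change from 2-bromo-3,5-dichlorophenyl to 5-bromo-2,3-dichlorophenyl on the sulfonamide nitrogen gives a 1.3-fold higher number from compound 3 to compound 4 (0.10 log units; within the scatter) and so cannot be told apart from no change; at this position, the same halogens can be redistributed over the ring without a readable effect on the number. Compound 4 also stays within the scatter of the 2,3,5-tribromophenyl analogue, with a 1.6-fold higher number from compound 2 to compound 4 (0.20 log units; within the scatter) as the step, so compound 2, compound 3 and compound 4 form one group that cannot be put in order. The step of a 6.3-fold higher number from compound 1 to compound 4 (0.80 log units; beyond the scatter) sets compound 4 apart from the 3,5-dichlorophenyl of compound 1 in the same direction as compound 2 and compound 3, and nothing measured here gives a reason for any of these steps.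

Still open, going by these compounds, is whether the 3,5-dichlorophenyl result of compound 1 is matched by 3,5-dibromophenyl or by unsubstituted phenyl. Also open, on these data alone, is how this position responds when the halogens give way to a different group, such as a methoxy group, a nitrile or an amine.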